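Adding One Fluoro to the More Potent Compound

The source may report more compounds than this note shows. Statements on the series, on what has been measured and on what is new or still open speak of the compounds shown alone.

Within the data shown here, in a functional assay on T29Kt1 cells (Homo sapiens) for cytotoxicity, read by sulforhodamine B assay, with a stated time of 3 days (a lower number here means a stronger inhibitor, a higher number a weaker inhibitor), compound 2 `OCc1cn(Cc2ccc(Cl)cc2)c2ccccc12` gives 79 nM, the lower of the two numbers measured so far. Compound 1 `O=Cc1cn(Cc2ccc(Cl)cc2)c2cc(F)ccc12` gives 9190 nM, a gap well beyond the usual scatter of repeat measurements. These two compounds differ in more than one place, so their gap does not give the size of any single change. The unmeasured compound 3 `OCc1cn(Cc2ccc(Cl)cc2)c2cc(F)ccc12` matches compound 2 except for one edit: fluoro in place of hydrogen on an aromatic carbon. Among the measured compounds shown here, no measured pair shows this change alone, so the expectation is only a rough one: a modest move toward a higher number, possibly none beyond the scatter. The estimated change is a 1.9-fold higher number from compound 2 to compound 3 (0.28 log units; within the scatter). For compound 3 the expected value is 150 nM, with a likely range from 30 nM to 1200 nM.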

Compound 3, half-maximal inhibitory concentration: 1000 nM
Estimate against measurement, compound 3: 6.7-fold (0.82 log units) below, within the range that was stated.
By their numbers in this assay, from the lowest: compound 2; then compound 3; then compound 1.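

In this assay fluoro in place of hydrogen on an aromatic carbon of the six-membered carbon ring proves to be no small edit: it gives a 13-fold higher number from compound 2 to compound 3 (1.10 log units; beyond the scatter) and shows that this position responds strongly to a single added atom. Compound 3 also lets the other change be read alone, since with the fluoro kept, hydroxymethyl in place of formyl gives a 9.2-fold lower number from compound 1 to compound 3 (0.96 log units; beyond the scatter) and so has a clear effect of its own, although a smaller one. Nothing measured here gives a reason for either step.

Fluoro is the only replacement for hydrogen shown at this carbon, so whether chloro or methoxy there would raise the number as much remains open. Also open, going by these compounds, is how an aminomethyl group or a carboxylic acid would compare with hydroxymethyl on the shared core.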